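This account rests on a few compounds, and the source may have more. Where it says the series, first, only, none or still open, it means among the compounds named here.

Measured in a functional assay on B16-F10 cells (Mus musculus) for antiproliferative activity, read by MTT assay, with a stated time of 48 h; on this read-out higher numbers stand for weaker inhibition and lower numbers for stronger inhibition:
- compound 1 `CC(=O)N1N=C(c2ccc3ccccc3c2)OC1c1cccc(Br)c1`: 2.36 ug/mL
- compound 2 `CC(=O)N1N=C(c2ccc3ccccc3c2)OC1c1ccccn1`: 7.18 ug/mL

Of these two compounds, compound 2 has the higher number, which means weaker inhibition. The next step leads to compound 3 `CC(=O)N1N=C(c2ccc3ccccc3c2)OC1c1ccncc1`, where pyridin-4-yl stands in place of pyridin-2-yl on a saturated ring carbon: pyridin-4-yl in place of pyridin-2-yl on a saturated ring carbon. Among the measured compounds shown here, only one measured step bears on this, and it is an imperfect guide. That step, a 3.0-fold higher number from compound 1 to compound 2 (0.48 log units; beyond the scatter), is modest and replaces 3-bromophenyl with pyridin-2-yl, a larger exchange than the one here. For the measured compounds named here, no measured pair shows what swapping one pyridine attachment for another does, so no direction can be favoured, and no step beyond the scatter is expected. For compound 3 the estimated value is 6.5 ug/mL, with an expected range of 2.5 ug/mL to 17 ug/mL. The expected change is thus a 1.1-fold lower number from compound 2 to compound 3 (0.04 log units; within the scatter).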

Compound 3, half-maximal inhibitory concentration: 2.97 ug/mL
Compound 3: middle estimate off by 2.2-fold (0.34 log units), on the high side; the range from low to high includes it.
By their numbers in this assay, from the lowest: compounds 1 and 3 (each within the scatter of the next); then compound 2.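

Swapping pyridin-2-yl for pyridin-4-yl keeps the same atoms yet gives a 2.4-fold lower number from compound 2 to compound 3 (0.38 log units; beyond the scatter) in this assay, so at this position the point of attachment of the pyridine ring affects the number, not just the presence of a pyridine. The weaker inhibition seen with pyridin-2-yl therefore does not hold for both pyridines, since pyridin-4-yl sits with 3-bromophenyl, with a 1.3-fold higher number from compound 1 to compound 3 (0.10 log units; within the scatter) and the two cannot be told apart. No measurement at hand explains why the two pyridines differ.

Still open, from the compounds shown here alone, is where pyridin-3-yl would fall, with pyridin-2-yl or with pyridin-4-yl. Going by these compounds, it is also open how a pyridine ring carrying an amine or a carboxylic acid would read at this position.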